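The compounds below may be only part of what the source reports. "The series", "measured", "known", "first", "only" and "open" are said of these compounds alone.

The three measured compounds share one core and differ only in the group on the amide-type nitrogen. Compound 1 `CNC(=O)CCSc1ccc2c(/C=C/c3ccccn3)n[nH]c2c1` carries a methyl there. In an ADME assay on BaF3 cells (Mus musculus) for antiproliferative activity, read by CCK-8 assay, with a stated time of 72 h (a lower number here means a stronger inhibitor of growth, a higher number a weaker inhibitor of growth), compound 1 gives only a limit of the assay, > 10000 nM. Compound 2 `O=C(CCSc1ccc2c(/C=C/c3ccccn3)n[nH]c2c1)Nc1cccc(F)c1` carries a 3-fluorophenyl and gives 6590 nM in this assay, one of just two numbers recorded. Compound 3 `COc1cccc(NC(=O)CCSc2ccc3c(/C=C/c4ccccn4)n[nH]c3c2)c1`, with a 3-methoxyphenyl, gives 3840 nM, and a 1.7-fold lower number from compound 2 to compound 3 (0.23 log units; within the scatter) stays within the scatter. The step of an at least 1.5-fold lower number from compound 1 to compound 2 (0.18 log units; that floor lies within the scatter) and the step of an at least 2.6-fold lower number from compound 1 to compound 3 (0.41 log units; beyond the scatter) both run toward lower numbers, the second beyond the scatter. Compound 4 `O=C(CCSc1ccc2c(/C=C/c3ccccn3)n[nH]c2c1)NCc1cccc(C(F)(F)F)c1` has not yet been measured; it differs from compound 2 as follows: 3-(trifluoromethyl)benzyl in place of 3-fluorophenyl on an amide-type nitrogen. Within the data shown here, no measured step tests a 3-(trifluoromethyl)benzyl directly; the aryl amide that set compound 2 and compound 3 apart from compound 1 is kept, and the nearest comparison, a 1.7-fold lower number from compound 2 to compound 3 (0.23 log units; within the scatter), was small. Compound 4 is therefore expected to stay near compound 2 in this assay, with an estimate of 5000 nM, between 2000 nM and 12500 nM. The step of a 1.3-fold lower number from compound 2 to compound 4 (0.12 log units; within the scatter) is expected to lie within the scatter.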

Compound 4, concentration for 50% growth inhibition: 8030 nM
Compound 4: middle estimate off by 1.6-fold (0.21 log units), on the low side; the measured number falls inside the stated range.
By their numbers in this assay, from the lowest: compounds 3, 2 and 4 (each within the scatter of the next, the first and the last beyond it). At a limit, above all of these: compound 1.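

In this assay, putting a 3-(trifluoromethyl)benzyl on the amide-type nitrogen in place of the 3-fluorophenyl gives a 1.2-fold higher number from compound 2 to compound 4 (0.09 log units; within the scatter), so this position takes the larger group, with its added heavy atoms, without a change beyond the scatter. The same group in place of the 3-methoxyphenyl gives a 2.1-fold higher number from compound 3 to compound 4 (0.32 log units; beyond the scatter), a modest separation. Against the methyl amide, the step, an at least 1.2-fold lower number from compound 1 to compound 4 (0.09 log units; that floor lies within the scatter), is only a floor, because compound 1 gives a limit: the limit of > 10000 nM in this assay, at which 1 of the 4 values shown sits.

This change swaps both the ring's substituent and the way the ring is attached to the nitrogen, so the two contributions cannot be told apart. As far as these compounds go, an unsubstituted benzyl or a 3-methoxybenzyl on the same nitrogen would separate them, and how a longer chain there would read remains open.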